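The source may report more compounds than this note shows. Statements on the series, on what has been measured and on what is new or still open speak of the compounds shown alone.

Compound 1 `N#Cc1ccc(N2CCc3cc(-c4cnc5ccccc5c4)ccc32)cc1C(F)(F)F`: "not determined" (no result reported) in a functional assay on VCaP cells (Homo sapiens) for antiproliferative activity, read by CCK-8 assay, with a stated time of 6 days; on this read-out higher numbers stand for weaker inhibition and lower numbers for stronger inhibition.
Compound 2 `N#Cc1ccc(N2CCCc3c(-c4ccncc4)cccc32)cc1C(F)(F)F`: > 30000 nM, which is a limit of the assay and not a number.
Compound 3 `CCN(c1ccc(C#N)c(Cl)c1)c1cc(-c2ccccc2)ccc1C`: > 30000 nM, again a limit of the assay rather than a number.

Compound 3 therefore stands at the edge of what this assay can report, and it is not alone there: the limit of > 30000 nM in this assay, at which 2 of the 3 values shown sit. Compound 4 `CCN(c1ccc(C#N)c(Cl)c1)c1cc(-c2cccnc2)ccc1C` differs from compound 3 in one place: pyridin-3-yl in place of phenyl on an aromatic carbon. Among the measured compounds shown here, no step between two measured compounds is available to show what such a swap does in this assay, so no shift beyond the usual scatter is expected in either direction. The step of a number no higher from compound 3 to compound 4 (the limit leaves the size open) is expected to be essentially flat. Compound 4 is estimated at 30000 nM, within a range of 6000 nM to 80000 nM, and most likely the assay will again report only a limit.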

Compound 4, half-maximal inhibitory concentration: 1270 nM
Compound 4: the middle estimate sits 24-fold (1.37 log units) above what was measured; the whole stated range lies above it.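

At this position, on an aromatic carbon para to a methyl group, pyridin-3-yl in place of phenyl gives an at least 23-fold lower number from compound 3 to compound 4 (1.37 log units; beyond the scatter) in this assay. A single ring nitrogen, with its one hydrogen-bond acceptor, is thus enough to turn a reading at the limit into a measurable value. Compound 3 gives only a limit, so the true size of the step stays unknown, and such limits are common here: the limit of > 30000 nM in this assay, at which 2 of the 4 values shown sit.

On these data alone, whether the acceptor itself drives this gain remains open. As far as these compounds go, it is also open whether a pyrimidine ring, or a phenyl ring carrying an amine, would act similarly at this position.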